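This account rests on a few compounds, and the source may have more. Where it says the series, first, only, none or still open, it means among the compounds named here.

Compound 1 `c1ccc(COc2ccccc2Nc2ncnc3cc4c(cc23)OCCOCCO4)cc1` in a functional assay on HepG2 cells (Homo sapiens) for antiproliferative activity, read by MTT assay, with a stated time of 72 h; a lower number here means a stronger inhibitor, a higher number a weaker inhibitor: > 100000 nM
Compound 2 `FC(F)(F)c1ccc(COc2ccc(Nc3ncnc4cc5c(cc34)OCCOCCO5)cc2)cc1` in this assay: > 100000 nM

Both entries are limits of the assay, not measured numbers. For compound 1 the value > 100000 nM is a limit, as the limit of > 100000 nM in this assay, at which 2 of the 2 values shown sit, shows. For compound 2 the value > 100000 nM is likewise a limit. Compound 1 therefore stands at the limit, with no number to rank it against anything. Compound 3 `O=[N+]([O-])c1ccc(COc2ccccc2Nc2ncnc3cc4c(cc23)OCCOCCO4)cc1` differs from compound 1 by nitro in place of hydrogen on an aromatic carbon. Among the measured compounds shown here, no step between measured compounds is known, so the step that the limit leaves unreadable from compound 1 to compound 3 is expected to be none beyond the scatter, leaving compound 3 at the limit. Compound 3 is thus estimated at 150000 nM, within 30000 nM to 1000000 nM.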

Compound 3, half-maximal inhibitory concentration: 50200 nM
Compound 3: middle estimate off by 3.0-fold (0.48 log units), on the high side, within the range that was stated.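

Among the compounds shown here, compound 3, with its 4-nitrobenzyl group, gives 50200 nM in this assay, the first actual number rather than a limit. Nitro in place of hydrogen gives an at least 1.9-fold lower number from compound 1 to compound 3 (0.29 log units; that floor lies within the scatter). That step is only a floor and its true size stays unknown, for the entry of compound 1 is a limit and not a number: the limit of > 100000 nM in this assay, at which 2 of the 3 values shown sit.

The compounds shown leave open how an amine, a carboxylic acid or a methoxy group would read at this same place. They also leave open whether any group there gives a much lower number than compound 3.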